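This account rests on a few compounds, and the source may have more. Where it says the series, first, only, none or still open, it means among the compounds named here.

The study concerns compound 3 `CC1CC/C(=N\Nc2ccc([N+](=O)[O-])cc2)c2ncc(C(=O)O)c(=O)n21` and its analogue compound 4 `CNC(=O)c1ccc(N/N=C2\CCC(C)n3c2ncc(C(=O)O)c3=O)cc1` in a functional assay on the whole organism for inhibition, with Rattus norvegicus as the target; on this read-out lower numbers stand for an effect already at smaller amounts and higher numbers for an effect only at larger amounts of compound. In this assay compound 3 gives only the limit > 320 umol/kg, so its standing among the numbers shown is a floor rather than a number. Compound 1 `CC1CC/C(=N\Nc2ccc(I)cc2)c2ncc(C(=O)O)c(=O)n21` gives the limit > 1000 umol/kg in this assay. Compound 2 `Cc1ccccc1N/N=C1\CCC(C)n2c1ncc(C(=O)O)c2=O` gives the limit > 100 umol/kg. Hence the step that the two limits leave unreadable from compound 1 to compound 2 and the step that the two limits leave unreadable from compound 1 to compound 3 are both unreadable, and neither bears readably on the change (methylcarbamoyl in place of nitro on an aromatic carbon). With three limits and no measured number, there is no ground for expecting a step in either direction beyond the scatter, so compound 4 is estimated at 500 umol/kg, between 100 umol/kg and 3000 umol/kg, with a further limit the likelier outcome. The expected step that the limit leaves unreadable from compound 3 to compound 4 therefore stands near nothing.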

Compound 4, dose for 50% inhibition: > 100 umol/kg
Compound 4: a limit, no number; the forecaster's own chance of this, stated with the estimate: 70%; the middle value does not contradict the limit.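

Compound 4, like compound 1 and compound 3, gives only a limit in this assay, so the steps from compound 1 and from compound 3 to compound 4 cannot be read. The compounds shown leave open what dose of any of them gives half inhibition, and whether methylcarbamoyl, nitro or iodo makes any difference.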